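Swapping Thiophene for Chlorophenyl at One Ring Carbon

A few compounds are considered here, and "the series" means these few. Any claim that something is new, unique, unknown or untested is made for them only; others in the source may bear on it.

Measured so far:
Compound 1 `Cc1ccc([C@@H]2CN(C)[C@]3(C(=O)Nc4ccccc43)[C@]23Cc2ccccc2C3=O)cc1`: 27.4%
Compound 2 `CN1C[C@@H](c2cccs2)[C@@]2(Cc3ccccc3C2=O)[C@@]12C(=O)Nc1ccccc12`: 32.6%

Of the compounds shown here, two sharing one core have been tested in a functional assay on the whole organism (strain Wister albino) for inhibition, with Rattus norvegicus as the target, read by paw edema, with stated times of 1 h and 3 h, at a dose of 50 mg/kg by the intraperitoneal route; on this read-out higher numbers stand for more inhibition at the one dose given (going by the name of the read-out) and lower numbers for less inhibition. In this assay compound 1 gives 27.4%, and compound 2 gives 32.6%. They differ only in the group on a saturated ring carbon, and the step of a number 5.2 percentage points higher from compound 1 to compound 2 (within the scatter) shows that this exchange moved the read-out by no more than repeated measurements usually do; compound 2 therefore stands with compound 1 rather than apart from it.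

Compound 3 `CN1C[C@@H](c2ccc(Cl)cc2)[C@@]2(Cc3ccccc3C2=O)[C@@]12C(=O)Nc1ccccc12` has not yet been measured. It keeps the core of compound 2 and alters the same spot: 4-chlorophenyl in place of thiophen-2-yl on a saturated ring carbon. Within the data shown here, the only measured step that bears on this is the one at the same saturated ring carbon, a number 5.2 percentage points higher from compound 1 to compound 2 (within the scatter), which lies within the scatter. Nothing in these two numbers separates one aromatic group at this spot from another, so the step of a number 2.6 percentage points lower from compound 2 to compound 3 (within the scatter) is expected to stay within the scatter as well. Compound 3 is therefore estimated at 30%, with a likely range from 20% to 41%.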

Compound 3, a percentage reported as inhibition, in the whole organism at one dose (the size of the read-out at that dose, not a potency): 18.9%
Compound 3: the middle estimate sits 11.1 percentage points above what was measured; the measured number lies below the stated range.
By their numbers in this assay, from the lowest: compounds 3, 1 and 2 (each within the scatter of the next, the first and the last beyond it).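

In this assay, putting 4-chlorophenyl in place of thiophen-2-yl on the saturated ring carbon gives a number 13.7 percentage points lower from compound 2 to compound 3 (beyond the scatter), so this position does respond to the choice of aromatic group, which the earlier pair could not show. The two phenyl compounds do not separate clearly: chloro in place of methyl on an aromatic carbon gives a number 8.5 percentage points lower from compound 1 to compound 3 (within the scatter), and because compound 1 also lies within the scatter of compound 2, only the two end compounds of the series stand apart. No measurement here offers an explanation for the gap that separates the thiophene compound from the chlorophenyl compound.

Every group shown at this carbon is aromatic, so it remains open whether an amine, a carboxylic acid or a longer chain such as n-butyl would keep the inhibition or lose it. Going by these compounds, it is also open whether plain phenyl, without chloro or methyl, would sit nearer to compound 2 or to compound 3, a comparison that would help show whether the ring itself or its chloro group matters more.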